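Swapping Fluoro for Methoxy in Compound 2

The compounds below may be only part of what the source reports. "The series", "measured", "known", "first", "only" and "open" are said of these compounds alone.

Of the compounds shown here, two sharing one core have so far been measured in an assay on CHO cells for displacement of a labelled ligand from prostacyclin receptor (Homo sapiens), read by scintillation counting, with a stated time of 30 min; a higher number here means a weaker inhibitor, a lower number a stronger inhibitor. Compound 1 `Cc1c(CC(=O)O)c2ccccc2n1C(=O)c1ccc(OC[C@@H]2CN(C)c3ccccc3O2)cc1` gives 200 nM in this assay. Compound 2 `Cc1c(CC(=O)O)c2ccccc2n1C(=O)c1ccc(OC[C@@H]2CN(C)c3ccccc3O2)c(F)c1` differs from it only by a fluoro in place of a hydrogen on an aromatic carbon, and in this assay compound 2 gives 210 nM. That single change produced a 1.1-fold higher number from compound 1 to compound 2 (0.02 log units; within the scatter), so compound 1 and compound 2 sit within the scatter of each other and neither can be called the stronger binder.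

Compound 3 `COc1cc(C(=O)n2c(C)c(CC(=O)O)c3ccccc32)ccc1OC[C@@H]1CN(C)c2ccccc2O1` is the next step from compound 2: methoxy in place of fluoro on an aromatic carbon. For the measured compounds named here, no measured step involves a methoxy, so there is no direct precedent for it. Going by the values given here, the only step at this position, a 1.1-fold higher number from compound 1 to compound 2 (0.02 log units; within the scatter), shows that this aromatic carbon tolerated a fluoro without a change beyond the scatter, which gives no reason to expect a large step in this assay from the larger methoxy either. Compound 3 is therefore expected to give about 250 nM in this assay, within a range of 110 nM to 600 nM. That estimate corresponds to an expected step of a 1.2-fold higher number from compound 2 to compound 3 (0.08 log units; within the scatter), within the scatter.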

Compound 3, inhibition constant: 430 nM
Compound 3: the middle estimate sits 1.7-fold (0.24 log units) below what was measured; the measured number falls inside the stated range.
By their numbers in this assay, from the lowest: compounds 1 and 2 (each within the scatter of the next); then compound 3.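

This aromatic carbon, ortho to a large group and meta to a large group, is not indifferent to what it carries: in this assay, fluoro left the number within the scatter of hydrogen, but methoxy does not stay there. Replacing fluoro with methoxy gives (  a 2.0-fold higher number from compound 2 to compound 3 (0.31 log units; beyond the scatter)  ), and replacing the original hydrogen with methoxy gives (  a 2.2-fold higher number from compound 1 to compound 3 (0.33 log units; beyond the scatter)  ), so both steps are modest but lie beyond the scatter, and compound 3 is the weakest binder of the three. No measurement among these compounds bears on why methoxy weakens binding here when fluoro does not.

The compounds shown leave open whether a chlorine, a methyl, a hydroxyl or an amine on this carbon would stay with hydrogen and fluoro or move the number as methoxy does. They also leave open whether a longer chain such as ethoxy would raise the number further, which would show whether this modest step is the start of a trend or a result for methoxy alone.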